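The compounds below may be only part of what the source reports. "The series", "measured", "known", "first", "only" and "open" are said of these compounds alone.

Measured so far in an in vivo functional assay on the whole organism for inhibition, with Rattus norvegicus as the target; on this read-out lower numbers stand for an effect already at smaller amounts and higher numbers for an effect only at larger amounts of compound:
- compound 1 `CCCCc1nc(C)c(CC(=O)N2CCSCC2)c(=O)n1Cc1ccc(-c2ccccc2-c2nnn[nH]2)cc1` gives 0.038 mg/kg
- compound 2 `CCCCc1nc(C)c(CCC(=O)N2CC(C)OC(C)C2)c(=O)n1Cc1ccc(-c2ccccc2-c2nnn[nH]2)cc1` gives 0.228 mg/kg

Compound 2 has the higher of the two numbers. Compound 3 `CCCCc1nc(C)c(CC(=S)N2CCCCCC2)c(=O)n1Cc1ccc(-c2ccccc2-c2nnn[nH]2)cc1` is not yet measured, and its change from compound 2 is a group of 9 heavy atoms (7 carbon, 1 nitrogen, 1 sulfur; one seven-membered non-aromatic ring with 1 hetero atom) in place of a group of 11 heavy atoms (8 carbon, 1 nitrogen, 2 oxygen; one six-membered non-aromatic ring with 2 hetero atoms), on a saturated chain carbon bound to an aromatic carbon at the same place. Going by the values given here, the only measured step there is a 6.0-fold higher number from compound 1 to compound 2 (0.78 log units; beyond the scatter) and it is modest. Neither measured compound carries the seven-membered non-aromatic ring, so the step gives only a rough guide. In this assay a modest move to a lower number is expected, and a 2.3-fold lower number from compound 2 to compound 3 (0.36 log units; beyond the scatter) is the estimated step. For compound 3 the estimate is 0.1 mg/kg and lies between 0.025 mg/kg and 0.4 mg/kg at the expected ends of its range.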

Compound 3, dose for half-maximal effect: 0.034 mg/kg
Beside the measured number, compound 3's estimate is 2.9-fold (0.47 log units) above it; the range from low to high includes it.
By their numbers in this assay, from the lowest: compounds 3 and 1 (each within the scatter of the next); then compound 2.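

In this assay, the group with the seven-membered non-aromatic ring gives a 6.7-fold lower number from compound 2 to compound 3 (0.83 log units; beyond the scatter), showing that this place on a saturated chain carbon bound to an aromatic carbon accepts a ring beyond the six-membered ones. Set against (thiomorpholin-4-yl)carbonyl, the same group gives a 1.1-fold lower number from compound 1 to compound 3 (0.05 log units; within the scatter), so the two groups are not told apart here. Nothing available explains either step. Ring, chain and thiocarbonyl differ together. The compounds leave open which of these carries the step from the dimethylmorpholine group. From the compounds shown here alone, how a carboxylic acid or an open-chain diethylamide would behave at this place also stays open.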